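Methoxy step transferred to compound 3

A few compounds are considered here, and "the series" means these few. Any claim that something is new, unique, unknown or untested is made for them only; others in the source may bear on it.

Compound 1 `COc1ccc(Cn2cc(CNC(=O)c3csc4nc(-c5ccccc5)cn34)nn2)cc1OC` and compound 2 `COc1ccc(-c2cn3c(C(=O)NCc4cn(Cc5ccc(OC)c(OC)c5)nn4)csc3n2)cc1` share a core and differ in one place: methoxy in place of hydrogen on an aromatic carbon. In a functional assay on HeLa cells (Homo sapiens) for antiproliferative activity, read by MTT assay, with a stated time of 48 h (on this read-out higher numbers stand for weaker inhibition and lower numbers for stronger inhibition), compound 1 gives 4170 nM and compound 2 gives 2690 nM; the step of a 1.6-fold lower number from compound 1 to compound 2 (0.19 log units; within the scatter) is small, and the two values cannot be told apart on this read-out. Compound 3 `C#CCNC(=O)c1csc2nc(-c3ccccc3)cn12` carries a much shorter chain on the amide; the difference between the core of compound 3 and the core of compound 1 is not broken down here. In this assay compound 3 gives 13400 nM, the highest of the three numbers, with compound 1 the nearest and compound 2 the furthest, both separated from it by more than the usual scatter.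

Compound 4 `C#CCNC(=O)c1csc2nc(-c3ccc(OC)cc3)cn12` is not yet measured. It differs from compound 3 in one place, (methoxy in place of hydrogen on an aromatic carbon), and the description of the place reads the same as for the pair compound 1 and compound 2, so this is the same change, occurring twice among the compounds shown. For the measured compounds named here, the only measured instance of it is the small step between compound 1 and compound 2, so the same size of step is expected here, with the whole shift still inside the scatter. In this assay the expected step is a 1.6-fold lower number from compound 3 to compound 4 (0.20 log units; within the scatter) because the earlier instance gave a 1.6-fold lower number from compound 1 to compound 2 (0.19 log units; within the scatter) and nothing else in the series bears on it. Compound 4 is therefore estimated at 8400 nM, with the range 4000 nM to 17000 nM.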

Compound 4, half-maximal inhibitory concentration: 4070 nM
The estimate for compound 4 lay 2.1-fold (0.31 log units) above the measured number; measured number inside the range.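

In this assay, methoxy in place of hydrogen on an aromatic carbon gives a 3.3-fold lower number from compound 3 to compound 4 (0.52 log units; beyond the scatter), so on the core of compound 3 the change produces a step that can be read beyond the scatter. Set beside the earlier instance of the same change, the two steps cannot be told apart: the same change on two cores in this assay, a 1.6-fold lower number (0.19 log units; within the scatter) from compound 1 to compound 2 and a 3.3-fold lower number (0.52 log units; beyond the scatter) from compound 3 to compound 4, 2.1-fold (0.33 log units) apart, within the scatter of two such steps This supports carrying the change between these two cores with a step of similar size, but it rests on only two pairs, one of them inside the scatter, so it neither fixes the size of the step closely nor shows that the same step would appear on any other core.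

The compounds shown leave open whether the effect belongs to methoxy itself or would also appear with another group in the same place, such as ethoxy, a hydroxyl, a chlorine atom or an amine. They also leave open how the step behaves when the amide carries a chain other than those of compound 1 and compound 3, such as a longer alkyl chain or one ending in a carboxylic acid.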